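The compounds below may be only part of what the source reports. "The series", "measured", "known", "first", "only" and "open" are said of these compounds alone.

Measured compounds:
compound 1, `CC(C)COc1ccc(NC(=O)CCCCCCCSc2nnc(Cc3nn(C)c(=O)c4ccccc34)n2C)cc1`, 4800 nM in an assay on isolated protein (Mus musculus) for inhibition of IL15-IL15 receptor (Homo sapiens), read by resazurin assay, with stated times of 30 min and 2.5 days; a higher number here means a weaker inhibitor, a lower number a stronger inhibitor
compound 2, `Cn1c(Cc2nn(C)c(=O)c3ccccc23)nnc1SCCCCCC(=O)Nc1ccc(Cl)cc1Cl`, 4100 nM in this assay
compound 3, `Cn1c(Cc2nn(C)c(=O)c3ccccc23)nnc1SCCCCCCCC(=O)Nc1ccccc1O`, 27000 nM in this assay

Among these three, compound 3 gives the highest number, and both of its neighbours lie well apart from it: a 5.6-fold higher number from compound 1 to compound 3 (0.75 log units; beyond the scatter) and a 6.6-fold higher number from compound 2 to compound 3 (0.82 log units; beyond the scatter) are each beyond the scatter, so compound 3 is the weakest inhibitor of the set. Compound 4, `Cc1ccc(NC(=O)CCCCCCCSc2nnc(Cc3nn(C)c(=O)c4ccccc34)n2C)c(Cl)c1`, has not yet been measured. It differs from compound 3 in one place: 2-chloro-4-methylphenyl in place of 2-hydroxyphenyl on an amide-type nitrogen. Compound 4 keeps the chain of compound 1 and carries an aryl group on the amide nitrogen that, like those of compound 1 and compound 2, lacks the hydroxyl of compound 3. Both measured steps therefore bear on this change, and both run in the same direction, with the hydroxyphenyl amide giving the higher number in each. Compound 4 is accordingly expected to return toward the level of compound 1 and compound 2, meaning a step of a 6.0-fold lower number from compound 3 to compound 4 (0.78 log units; beyond the scatter). The estimate for compound 4 is 4500 nM, with a range from 1500 nM to 14000 nM.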

Compound 4, half-maximal inhibitory concentration: 2300 nM
Compound 4: middle estimate off by 2.0-fold (0.29 log units), on the high side; measured number inside the range.
By their numbers in this assay, from the lowest: compounds 4, 2 and 1 (each within the scatter of the next, the first and the last beyond it); then compound 3.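

On the amide-type nitrogen, 2-chloro-4-methylphenyl in place of 2-hydroxyphenyl gives a 12-fold lower number from compound 3 to compound 4 (1.07 log units; beyond the scatter) in this assay and is the largest step seen so far, so with the chain held constant this position can move the number substantially. The hydroxyl-free aryl groups are not interchangeable either, since 2-chloro-4-methylphenyl in place of 4-(isobutoxy)phenyl gives a 2.1-fold lower number from compound 1 to compound 4 (0.32 log units; beyond the scatter) on the same chain, a smaller step that is still beyond the scatter. Nothing shown here explains either step.

The compounds shown do not separate the loss of the hydroxyl from the arrival of the chlorine and the methyl, which a plain phenyl, a 2-chlorophenyl or a 4-methylphenyl on this nitrogen would begin to do. Going by these compounds, it also remains open how a 2-aminophenyl or a 2-methoxyphenyl would compare with the 2-hydroxyphenyl of compound 3.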